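The source may hold more compounds than are shown below. What is called first, only, known or untested is meant among the compounds shown, and "the series" means these compounds.

Measured in a functional assay on U-87MG ATCC cells for antiproliferative activity against U-87 MG (Homo sapiens), read by MTT assay, with a stated time of 48 h; on this read-out higher numbers stand for weaker inhibition and lower numbers for stronger inhibition:
- compound 1 `Cc1nc(-c2ccc(Cl)cc2)sc1C(=O)CSc1nc(-c2ccccc2)c(C#N)c(=O)[nH]1`: 27600 nM
- compound 2 `Cc1nc(-c2ccccc2)sc1C(=O)CSc1nc(-c2ccccc2)c(C#N)c(=O)[nH]1`: 56600 nM

Compound 1 holds the lower number of the two. Compound 3 `Cc1nc(-c2ccc(Cl)cc2)sc1C(=O)CSc1nc(-c2ccc(Cl)cc2)c(C#N)c(=O)[nH]1` differs from compound 1 by chloro in place of hydrogen on an aromatic carbon: phenyl to 4-chlorophenyl, chloro in place of hydrogen on an aromatic carbon. For the measured compounds named here, the only measured step that bears on this is a 2.1-fold higher number from compound 1 to compound 2 (0.31 log units; beyond the scatter), the same exchange run in reverse at another aromatic ring. A similarly modest step toward a lower number is therefore expected, on thin evidence. The expected step is a 1.8-fold lower number from compound 1 to compound 3 (0.26 log units; within the scatter). In this assay the estimate for compound 3 is 15000 nM, with an expected range of 6000 nM to 38000 nM.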

Compound 3, half-maximal inhibitory concentration: 53000 nM
Estimate against measurement, compound 3: 3.5-fold (0.55 log units) below; the measured number lies above the stated range.
By their numbers in this assay, from the lowest: compounds 1, 3 and 2 (each within the scatter of the next, the first and the last beyond it).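

In this assay, phenyl to 4-chlorophenyl at this position gives a 1.9-fold higher number from compound 1 to compound 3 (0.28 log units; within the scatter). The same exchange at the other aromatic ring, read in reverse as a 2.1-fold higher number from compound 1 to compound 2 (0.31 log units; beyond the scatter), lies beyond the scatter, so in these compounds a chloro step at one ring does not carry over to the other. Nothing available accounts for this difference between the two rings. On these data alone, whether a methoxy group or an amine at this position would move the number beyond the scatter remains open. So does whether a fluoro group would behave as chloro does here.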